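Notes on the cyano-aminopyridine sulfonamide series: step to compound 4

The compounds below may be only part of what the source reports. "The series", "measured", "known", "first", "only" and "open" are said of these compounds alone.

Measured so far:
compound 1 `Cc1ccc(C2C(C#N)=C(N)N(c3ccc(S(N)(=O)=O)cc3)C3=C2C(=O)CCC3)cc1` — 30%
compound 2 `N#CC1=C(N)N(c2ccc(S(N)(=O)=O)cc2)C2=C(C(=O)CCC2)C1c1ccc(O)cc1` — 90%
compound 3 `COc1cc(CC2C(C#N)=C(N)N(c3ccc(S(N)(=O)=O)cc3)C3=C2C(=O)CCC3)ccc1O` — 0%

All three were tested in a functional assay on Ehrlich cells (Mus musculus) for antiproliferative activity, read by trypan blue exclusion, with a stated time of 2 h, tested at 10 ug/mL; on this read-out lower numbers stand for a weaker effect and higher numbers for a stronger effect at the one concentration tested. Compound 3 stands lowest of the three numbers: its nearest neighbour is compound 1, with a number 30 percentage points lower from compound 1 to compound 3 (beyond the scatter), and the furthest is compound 2, with a number 90 percentage points lower from compound 2 to compound 3 (beyond the scatter). Between compound 1 and compound 2 the change is a number 60 percentage points higher from compound 1 to compound 2 (beyond the scatter).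

The unmeasured compound 4 `N#CC1=C(N)N(c2ccc(S(N)(=O)=O)cc2)C2=C(C(=O)CCC2)C1c1cccc([N+](=O)[O-])c1` differs from compound 3 by 3-nitrophenyl in place of 4-hydroxy-3-methoxybenzyl on a saturated ring carbon.

Both steps that end at compound 3 bear on this one, since each replaced a directly attached aryl group with the 4-hydroxy-3-methoxybenzyl group and each lowered the number well beyond the scatter. Going by the values given here, compound 4 puts a directly attached aryl group back in that place, so a rise is expected, of a size somewhere between the two measured drops, though no measured compound carries a 3-nitrophenyl group and the spread between compound 1 and compound 2 shows that the aryl substituent alone moves the number widely. For compound 4 the expected step is a number 50 percentage points higher from compound 3 to compound 4 (beyond the scatter), and the estimated value is 50%, within a range from 10% to 90%.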

Compound 4, a percentage reported as activity, at one concentration (the size of the read-out at that concentration, not a potency): 42%
For compound 4 the middle estimate is 8 percentage points above the measured one; low and high end bracket the measured number.
By their numbers in this assay, from the lowest: compound 3; then compound 1; then compound 4; then compound 2.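

In this assay the 3-nitrophenyl group on the saturated ring carbon gives a number 42 percentage points higher from compound 3 to compound 4 (beyond the scatter), so all three aryl groups bonded directly at this position now stand above the 4-hydroxy-3-methoxybenzyl group of compound 3. The new group also separates from the other two aryl groups, with a number 12 percentage points higher from compound 1 to compound 4 (beyond the scatter) and a number 48 percentage points lower from compound 2 to compound 4 (beyond the scatter), which leaves 4-hydroxyphenyl the strongest of the four groups here, although a hydroxy group alone does not carry the effect: compound 3 has one and stands lowest, while compound 4 has none and stands above compound 1. Nothing on hand accounts for these differences.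

On these data alone, it remains open whether the low number of compound 3 goes with the benzyl group as such or with its hydroxy and methoxy substituents, a question that an unsubstituted benzyl group and a 4-hydroxybenzyl group would settle. Also open, as far as these compounds go, is how much depends on where the substituent sits on the phenyl ring and on what it is, which 4-nitrophenyl, 3-hydroxyphenyl, 3-aminophenyl and unsubstituted phenyl groups would test.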